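A Dimethylamino Swap on the Outer Aromatic Ring

This account rests on a few compounds, and the source may have more. Where it says the series, first, only, none or still open, it means among the compounds named here.

Of the compounds shown here, two have so far been measured in a functional assay on IGROV-1 cells (Homo sapiens) for cytotoxicity, read by sulforhodamine B assay, with a stated time of 48 h, tested at 1 uM; a lower number here means a stronger effect, a higher number a weaker effect of the compound at the concentration tested. Compound 1 `COc1cc(C)cc(-c2nn(CC#N)cc2-c2ccc(-c3cccc(C(C)=O)c3)nc2)c1` gives 1%. Compound 2 `Cc1cc(O)cc(-c2nn(CC#N)cc2-c2ccnc(-c3ccc(Oc4ccccc4)cc3)c2)c1` gives -64%, the lowest of the two numbers, and its gap to compound 1 lies beyond the scatter. Compound 3 `Cc1cc(O)cc(-c2nn(CC#N)cc2-c2ccnc(-c3ccc(N(C)C)cc3)c2)c1` has not yet been measured in this assay. It differs from compound 2 in one place: dimethylamino in place of phenoxy on an aromatic carbon. Within the data shown here, no measured step of this kind exists, so its size is uncertain; a move toward a weaker effect, beyond the scatter, is expected. Compound 3 is estimated to give -20%, with a range from -70% to 30%. The step this estimate means, a number 44 percentage points higher from compound 2 to compound 3 (beyond the scatter), is expected to exceed the scatter.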

Compound 3, a percentage reported as activity, at one concentration (the size of the read-out at that concentration, not a potency): 24%
The estimate for compound 3 lay 44 percentage points below the measured number; low and high end bracket the measured number.
By their numbers in this assay, from the lowest: compound 2; then compound 1; then compound 3.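

In this assay, dimethylamino in place of phenoxy on an aromatic carbon, para to a large group, gives a number 88 percentage points higher from compound 2 to compound 3 (beyond the scatter), a large step. The outcome at this position therefore depends strongly on the group placed there, and the rest of compound 2 does not by itself preserve its low number. Nothing shown here explains the step. Still open, as far as these compounds go, is whether benzyloxy, which also carries an aromatic ring, would keep the number of compound 2. Morpholine or methoxy at this place also remains untested in the compounds shown.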